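Sulfamoyl for nitro on a pyrazolopyrimidinone anti-inflammatory series

The source may report more compounds than this note shows. Statements on the series, on what has been measured and on what is new or still open speak of the compounds shown alone.

Measured compounds:
compound 1, `CSc1nn(-c2ccc([N+](=O)[O-])cc2)c2nc(Nc3ccccc3)n(-c3ccccc3)c(=O)c12`, in a functional assay on the whole organism (strain Wistar albino) for inhibition, with Rattus norvegicus as the target, read by paw edema, with a stated time of 2 h, at a dose of 25 mg/kg by the oral route (on this read-out higher numbers stand for more inhibition at the one dose given (going by the name of the read-out) and lower numbers for less inhibition), gives 37.7%
compound 2, `CSc1nn(-c2ccc(S(N)(=O)=O)cc2)c2nc(Nc3ccccc3)n(-c3ccccc3)c(=O)c12`, in this assay gives 54.1%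
compound 3, `Cc1ccc(Nc2nn(-c3ccc([N+](=O)[O-])cc3)c3nc(Nc4ccccc4)n(-c4ccccc4)c(=O)c23)cc1`, in this assay gives 39.8%

Among the compounds with values here, the one change that is seen twice in the set is sulfamoyl in place of nitro on an aromatic carbon. Between the two measured compounds carrying it the step is a number 16.4 percentage points higher from compound 1 to compound 2 (beyond the scatter).

The cores of compound 1 and compound 3 differ by (4-methylphenyl)amino in place of methylsulfanyl on an aromatic carbon; the step that goes with this is a number 2.1 percentage points higher from compound 1 to compound 3 (within the scatter), so the two cores cannot be told apart on this read-out. Within the data shown here, compound 2 and compound 3 have no step counted between them; their values show only that compound 2 sits beyond the scatter above compound 3.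

Compound 4, `Cc1ccc(Nc2nn(-c3ccc(S(N)(=O)=O)cc3)c3nc(Nc4ccccc4)n(-c4ccccc4)c(=O)c23)cc1`, is not yet measured. It differs from compound 3 by sulfamoyl in place of nitro on an aromatic carbon. The place line is the same, word for word, as for the step from compound 1 to compound 2, so this is the same change made on the core of compound 3. The expectation for compound 3 to compound 4 is a step of about a number 15.2 percentage points higher from compound 3 to compound 4 (beyond the scatter), which rests on the measured step of a number 16.4 percentage points higher from compound 1 to compound 2 (beyond the scatter) and on the cores of compound 1 and compound 3 being indistinguishable in this assay. The estimate for compound 4 is therefore 55%, with a range from 43% to 67%.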

Compound 4, a percentage reported as inhibition, in the whole organism at one dose (the size of the read-out at that dose, not a potency): 63.4%
Compound 4: middle estimate off by 8.4 percentage points, on the low side; low and high end bracket the measured number.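

In this assay, sulfamoyl in place of nitro carries over to the second core, the new step being a number 23.6 percentage points higher from compound 3 to compound 4 (beyond the scatter), and its size agrees with the step seen on the first core: the same change on two cores in this assay, a number 16.4 percentage points higher (beyond the scatter) from compound 1 to compound 2 and a number 23.6 percentage points higher (beyond the scatter) from compound 3 to compound 4, 7.2 percentage points apart, within the scatter of two such steps

Read the other way round, (4-methylphenyl)amino in place of methylsulfanyl stays as silent among the sulfamoyl compounds, at a number 9.3 percentage points higher from compound 2 to compound 4 (within the scatter), as it was among the nitro compounds, so the two changes behave here as independent of each other: the same change on two cores in this assay, a number 2.1 percentage points higher (within the scatter) from compound 1 to compound 3 and a number 9.3 percentage points higher (within the scatter) from compound 2 to compound 4, 7.2 percentage points apart, within the scatter of two such steps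

This rests on two cores and four compounds at a single dose and a single time, so it shows transfer between these two cores only; it gives no reason for the gain, does not show that the step differs in size from one core to the other, and does not rank compound 2 and compound 4, which lie within the scatter of each other.

Whether the gain is particular to sulfamoyl stays open, since a methylsulfonyl group, a carboxylic acid or an amine on the same aromatic carbon, para to a large group, does not appear among these compounds. From the compounds shown here alone, it is also open whether the step would hold on a core carrying a longer chain or an amine in place of methylsulfanyl, and how it would look at other doses.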